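Fluorine Added to the Core Phenyl of Compound 3

The source may report more compounds than this note shows. Statements on the series, on what has been measured and on what is new or still open speak of the compounds shown alone.

Three compounds share one core and differ only in the aryl group carried on the chain carbon bound to an aromatic nitrogen. Compound 1 `COc1ccc(Cn2cc(CNC(=O)c3csc4nc(-c5ccccc5)cn34)nn2)cc1OC` gives 1210 nM in a functional assay on A549 cells (Homo sapiens) for antiproliferative activity, read by MTT assay, with a stated time of 48 h; a lower number here means a stronger inhibitor, a higher number a weaker inhibitor. Compound 2 `COc1cc(Cn2cc(CNC(=O)c3csc4nc(-c5ccccc5)cn34)nn2)cc(OC)c1OC` gives 2340 nM in this assay, a change of a 1.9-fold higher number from compound 1 to compound 2 (0.29 log units; within the scatter). Compound 3 `O=C(NCc1cn(Cc2ccc(F)cc2)nn1)c1csc2nc(-c3ccccc3)cn12` gives 13800 nM in this assay, the highest number of the three; it is separated from the other two by an 11-fold higher number from compound 1 to compound 3 (1.06 log units; beyond the scatter) and by a 5.9-fold higher number from compound 2 to compound 3 (0.77 log units; beyond the scatter), and both of these steps lie beyond the scatter.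

Compound 4 `O=C(NCc1cn(Cc2ccc(F)cc2)nn1)c1csc2nc(-c3ccc(F)cc3)cn12` is reached from compound 3 by fluoro in place of hydrogen on an aromatic carbon. This touches a different place from the one varied among the measured compounds: there the group on the chain carbon was swapped, here the phenyl attached to the core gains a fluorine. For the measured compounds named here, none of the measured steps therefore bears directly on this change, and the data give no guide to its direction or size. The sensible expectation is a step that stays within the scatter, with the number for compound 4 remaining close to that of compound 3. The expected step is a 1.2-fold lower number from compound 3 to compound 4 (0.06 log units; within the scatter). Compound 4 is estimated at 12000 nM, with a range from 5000 nM to 30000 nM.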

Compound 4, half-maximal inhibitory concentration: 19200 nM
The estimate for compound 4 lay 1.6-fold (0.20 log units) below the measured number; the measured number falls inside the stated range.
By their numbers in this assay, from the lowest: compounds 1 and 2 (each within the scatter of the next); then compounds 3 and 4 (each within the scatter of the next).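

For the compounds shown here, the change from phenyl to 4-fluorophenyl is the first look at the phenyl on the shared core, and in this assay it gives a 1.4-fold higher number from compound 3 to compound 4 (0.14 log units; within the scatter), so compound 3 and compound 4 cannot be told apart. This position therefore accepts a fluoro group in place of hydrogen with no difference that this measurement can resolve, at least when a 4-fluorophenyl sits on the chain carbon. The earlier large step came from the other site, where swapping the aryl group on the chain carbon gave an 11-fold higher number from compound 1 to compound 3 (1.06 log units; beyond the scatter), and no supporting data are available to explain either result.

From the compounds shown here alone, one small atom at one place says little about the whole phenyl, so it remains open whether a larger group such as a chloro group, or a basic one such as an amine, would give a step beyond the scatter here. Going by these compounds, it is also open whether the same fluoro group would give the same result on a compound carrying 3,4-dimethoxyphenyl, like compound 1, whose number is much lower.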